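A few compounds are considered here, and "the series" means these few. Any claim that something is new, unique, unknown or untested is made for them only; others in the source may bear on it.

Measured so far in an ADME assay on microsomes from liver (Homo sapiens) for metabolic stability, read by LC-MS, using NADPH, with a stated time of 45 min, tested at 0.5 uM; a higher number here means faster removal of the compound, a lower number slower removal:

compound 1 `Clc1ccc2oc(SCCCN3CCCC3)nc2c1`, 1.9 mL/min/g
compound 2 `CC1CCN(C(=O)CCSc2nc3cc(Cl)ccc3o2)C1`, 10.1 mL/min/g

Of these two numbers, compound 2 stands highest in this assay; the nearest, compound 1, gives a value that sits well beyond the scatter below it.

Compound 3 `CN(C)C(=O)CCSc1nc2cc(Cl)ccc2o1` has not yet been measured in this assay. It differs from compound 2 in one place: dimethylamino in place of 3-methylpyrrolidin-1-yl on a carbonyl carbon.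

For the measured compounds named here, no step between measured compounds covers this change, so the expectation rests on compound 2 alone. A modest step downward, toward slower removal, is expected, about a 2.0-fold lower number from compound 2 to compound 3 (0.31 log units; beyond the scatter). For compound 3 the number in this assay is estimated at 5 mL/min/g, within a range of 2.5 mL/min/g to 10 mL/min/g.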

Compound 3, intrinsic clearance in a liver preparation (reported as CLH), per the amount of preparation that the assay uses: 2.7 mL/min/g
For compound 3 the middle estimate is 1.9-fold (0.27 log units) above the measured one; the range from low to high includes it.
By their numbers in this assay, from the lowest: compounds 1 and 3 (each within the scatter of the next); then compound 2.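

In this assay the group on the carbonyl carbon proves to be a sensitive point: dimethylamino in place of 3-methylpyrrolidin-1-yl gives a 3.7-fold lower number from compound 2 to compound 3 (0.57 log units; beyond the scatter). Dimethylcarbamoyl in place of (pyrrolidin-1-yl)methyl on the saturated chain carbon gives a 1.4-fold higher number from compound 1 to compound 3 (0.15 log units; within the scatter), so these two side chains are not separated in this assay. No supporting data bear on the cause of either step.

Still open, on these data alone, is how an unsubstituted amide or a carboxylic acid would read on this carbonyl carbon. Also open, as far as these compounds go, is where pyrrolidin-1-yl without its methyl would fall.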